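The compounds below may be only part of what the source reports. "The series", "measured", "known", "first", "only" and "open" are said of these compounds alone.

Measured compounds:
compound 1, `OC1CN(Cc2ccc(Br)cc2)CCC1N1CCN(c2ccccc2)CC1` — > 100 nM
compound 2, `OC1CCN(Cc2ccc(Br)cc2)CC1N1CCN(c2ccccc2)CC1` — > 100 nM

In an assay on PC-12 cells for displacement of a labelled ligand from vesicular acetylcholine transporter (Homo sapiens) (a lower number here means a stronger inhibitor, a higher number a weaker inhibitor), compound 1 gives only a limit, > 100 nM. Compound 2 likewise gives only a limit in this assay, namely > 100 nM. Both values thus sit at the limit of > 100 nM in this assay, at which 2 of the 2 values shown sit, and the pair says nothing about which is the stronger inhibitor. Compound 3, `C#CCN1CCC(O)C(N2CCN(c3ccccc3)CC2)C1`, differs from compound 2 by ethynyl in place of 4-bromophenyl on a saturated chain carbon bound to an amine nitrogen in a ring, the same difference read one bond further out as 4-bromobenzyl to propargyl. Within the data shown here, no measured step covers such a change, so from compound 2 to compound 3 the estimated step is a step that the limit leaves unreadable from compound 2 to compound 3, with no direction expected beyond the scatter. Compound 3 is expected to give 400 nM in this assay, in the range 60 nM to 3000 nM.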

Compound 3, half-maximal inhibitory concentration: > 100 nM
Compound 3: only a limit was reported (the forecaster's own chance of this, stated with the estimate: 70%); the middle value lies beyond the limit too.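

Compound 3 gives > 100 nM in this assay and this is only a limit, so no step can be read between compound 2 and compound 3. The compounds shown leave open how strongly any of them inhibits, and whether ethynyl or 4-bromophenyl gives the stronger inhibitor.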